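Swapping the thiophene on a phenoxymethyl imidazoline core

This account rests on a few compounds, and the source may have more. Where it says the series, first, only, none or still open, it means among the compounds named here.

Compound 1, `c1ccc(-c2ccncn2)c(OCC2=NCCN2)c1`: < 100000 nM
Compound 2, `c1ccc(-c2ccsc2)c(OCC2=NCCN2)c1`: 0.251 nM

Two compounds have been run in a functional assay for activation of Alpha-1A adrenergic receptor (Homo sapiens), read by calcium flux; a lower number here means that less compound is needed, a higher number that more compound is needed for the effect. For compound 1 the assay returns only a limit, < 100000 nM, not a number. Going by the values given here, compound 2 gives 0.251 nM, the only true number in the set. Among the compounds with values here, the one measured step, a step that the limit leaves unreadable from compound 1 to compound 2, therefore cannot be sized, since one end of it is fixed by the limit of < 100000 nM in this assay, at which 1 of the 2 values shown sits. Within the data shown here, compound 2 thus stands alone as the sole compound with a readable value, and it is the reference for what follows.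

Compound 3, `Cc1ccc(-c2ccccc2OCC2=NCCN2)s1`, is not yet measured. It differs from compound 2 in one place: 5-methylthiophen-2-yl in place of thiophen-3-yl on an aromatic carbon. Among the measured compounds shown here, no measured step touches this kind of change, so nothing in the data sizes its effect. The starting point is a very low concentration, and a change of a small thiophene substituent is expected to move the number by no more than a modest amount in either direction. Compound 3 is expected to give 0.5 nM, within 0.1 nM to 3 nM, which means an expected step of a 2.0-fold higher number from compound 2 to compound 3 (0.30 log units; within the scatter).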

Compound 3, half-maximal effective concentration: 25.1 nM
Compound 3: the middle estimate sits 50-fold (1.70 log units) below what was measured, outside the stated range (above it).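

In this assay, on an aromatic carbon of a six-membered aromatic ring of carbon only, ortho to a group of 7 heavy atoms, putting 5-methylthiophen-2-yl in place of thiophen-3-yl gives a 100-fold higher number from compound 2 to compound 3 (2.00 log units; beyond the scatter). Going by these compounds alone, this is the first step of readable size at this position, and it shows that the number responds strongly even to an exchange between two closely matched groups: each is one five-membered aromatic ring with 1 hetero atom, and the heavy-atom count goes only from 5 to 6. Compound 1 carries a limit and not a number, and its steps to compound 2 and compound 3 cannot be read because of it: the limit of < 100000 nM in this assay, at which 1 of the 3 values shown sits.

The single step changes both the point of attachment on the thiophene and the presence of the methyl, and the compounds shown do not separate these two changes. A plain thiophen-2-yl would be needed to divide the step between them, while a phenyl or furan-3-yl group at the same place would show how far the low number of compound 2 depends on the thiophene itself.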